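This account rests on a few compounds, and the source may have more. Where it says the series, first, only, none or still open, it means among the compounds named here.

Measured so far:
compound 1, `COc1cc2c(cc1OC)C(CC(=O)O)CC2`: 44%
compound 2, `COc1cc2c(cc1OC)C(CC(N)=O)CC2`: 24.6%

In a functional assay on the whole organism (strain Swiss albino) for inhibition, with Mus musculus as the target, in the writhing test, with stated times of 60 min and 15 min, at a dose of 100 mg/kg by the oral route (on this read-out lower numbers stand for less inhibition and higher numbers for more inhibition at the one dose given (going by the name of the read-out)), compound 1 gives 44%, while compound 2 gives 24.6%, the lower of the two numbers. Going by the values given here, the only step known here, a number 19.4 percentage points lower from compound 1 to compound 2 (beyond the scatter), comes with amino in place of hydroxy on a carbonyl carbon. Compound 3, `CNC(=O)CC1CCc2cc(OC)c(OC)cc21`, differs from compound 2 by methyl in place of hydrogen on an amide-type nitrogen. Among the compounds with values here, no measured step touches an amide-type nitrogen, so the step from compound 1 to compound 2 bears on the new change only loosely: it shows that a small alteration at the carbonyl carbon shifted this assay modestly. For compound 3, therefore, a step within the scatter, or at most a modest one in either direction, is expected, a number 2.6 percentage points lower from compound 2 to compound 3 (within the scatter). Compound 3 is estimated at 22%, with a range from 5% to 40%.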

Compound 3, a percentage reported as inhibition, in the whole organism at one dose (the size of the read-out at that dose, not a potency): 21.2%
Compound 3: the middle estimate sits 0.8 percentage points above what was measured; the measured number falls inside the stated range.
By their numbers in this assay, from the lowest: compounds 3 and 2 (each within the scatter of the next); then compound 1.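

In this assay, methyl in place of hydrogen on an amide-type nitrogen gives a number 3.4 percentage points lower from compound 2 to compound 3 (within the scatter), so at this nitrogen the amide hydrogen can give way to methyl with no change that stands out from the scatter. Methylamino in place of hydroxy on a carbonyl carbon gives a number 22.8 percentage points lower from compound 1 to compound 3 (beyond the scatter), which shows that the amide with methyl on its nitrogen, like the amide of compound 2, stays apart from the carboxylic acid of compound 1. No available evidence bears on this result.

The compounds shown leave open whether an ethyl group, a second methyl on the same nitrogen or a ring amine such as morpholine would shift the number. They also leave open how a methyl ester in place of the hydroxy of compound 1 would compare.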